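Fixing One Stereocentre on the Way to a Single Isomer

A few compounds are considered here, and "the series" means these few. Any claim that something is new, unique, unknown or untested is made for them only; others in the source may bear on it.

Two compounds have so far been characterised in an assay on CHO cells for displacement of a labelled ligand from D(4) dopamine receptor (Homo sapiens); a higher number here means a weaker inhibitor, a lower number a stronger inhibitor. Compound 1 `COc1c(-c2nc(CNC[C@@H]3CCN(Cc4ccccc4)C3)co2)cc(Br)c2ccccc12` gives 15500 nM in this assay, whereas compound 2 `COc1ccc(Br)cc1-c1nc(CNCCC2CCN(Cc3ccccc3)C2)co1` gives 150 nM. Compound 2 therefore holds the lower of the two numbers, and compound 1 stands far above it, a gap well beyond the usual scatter.

Compound 3 `COc1ccc(Br)cc1-c1nc(CNCC[C@@H]2CCN(Cc3ccccc3)C2)co1` remains to be measured. It is related to compound 2 as follows: the two compounds have the same atoms and bonds; at least one stereo element is drawn with a configuration in one of them and without one in the other: 1 of 1 stereo elements differ; a stereocentre at a saturated ring carbon is drawn without a configuration in compound 2 and R in compound 3. Among the compounds with values here, no measured pair in this set differs in only one place, so there is no measured step to lean on for a change of this kind. Since nothing leaves and nothing enters, and only the drawn configuration at one saturated ring carbon is fixed, no step beyond the scatter is expected in this assay, though a modest shift in either direction remains possible depending on which isomer carries the activity of compound 2. Compound 3 is estimated to give about 110 nM in this assay, within a range of 40 nM to 450 nM. The expected step of a 1.4-fold lower number from compound 2 to compound 3 (0.13 log units; within the scatter) is thus within the scatter.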

Compound 3, inhibition constant: 170 nM
Compound 3: the middle estimate sits 1.5-fold (0.19 log units) below what was measured, within the range that was stated.
By their numbers in this assay, from the lowest: compounds 2 and 3 (each within the scatter of the next); then compound 1.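

In this assay, within the data shown here, the result is a 1.1-fold higher number from compound 2 to compound 3 (0.05 log units; within the scatter), the first step in this set that changes one place only. It shows that a compound with this saturated ring carbon drawn as R cannot be told apart from compound 2, which is drawn without a configuration there; compounds 1 and 2 differ in more than one place, so their gap could not show this. The comparison turns on a single difference between the two structures: the fact that one of compounds 2 and 3 is drawn with a defined configuration and the other without, at the place where they differ.

The compounds shown leave open how the S configuration at this ring carbon reads, and so whether the two configurations differ at all. They also leave open what a methyl group on this same ring carbon would do to the number in this assay.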